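This account rests on a few compounds, and the source may have more. Where it says the series, first, only, none or still open, it means among the compounds named here.

Working notes on the series. Compound 2 `O=C(O)c1ccc(CN2C(=O)S/C(=C\c3cccs3)C2=O)cc1` gives 80000 nM in a functional assay on A549 cells (Homo sapiens) for cytotoxicity, read by MTT assay, with a stated time of 24 h; a higher number here means a weaker inhibitor, a lower number a stronger inhibitor. Among the compounds with values here, the only other measured member is compound 1 `O=C(O)c1ccc(CN2C(=O)S/C(=C\c3cccnc3)C2=O)cc1`, which in this assay gives 75000 nM; the two numbers lie within the scatter of each other, so compound 2 cannot be placed apart from compound 1 on the numbers so far. Within the data shown here, the single step available, a 1.1-fold higher number from compound 1 to compound 2 (0.03 log units; within the scatter), swapped one aromatic ring for another at the same place without moving the number beyond the scatter.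

Compound 3 `O=C(O)c1ccc(CN2C(=O)S/C(=C\c3ccco3)C2=O)cc1` is the next member, not yet measured. The change is furan-2-yl in place of thiophen-2-yl on a double-bonded chain carbon bound to a double-bonded ring carbon. Among the measured compounds shown here, the one step that bears on it, a 1.1-fold higher number from compound 1 to compound 2 (0.03 log units; within the scatter), was flat, so for compound 3 an equally flat step is expected: no change at the digits printed from compound 2 to compound 3 (within the scatter), with no direction beyond the scatter. The estimate for compound 3 in this assay is therefore 80000 nM, within the range 40000 nM to 160000 nM.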

Compound 3, half-maximal inhibitory concentration: 76000 nM
Compound 3: the middle estimate sits 1.1-fold (0.02 log units) above what was measured; measured number inside the range.
By their numbers in this assay, from the lowest: compounds 1, 3 and 2 (each within the scatter of the next).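

In this assay, furan-2-yl in place of thiophen-2-yl gives a 1.1-fold lower number from compound 2 to compound 3 (0.02 log units; within the scatter), and furan-2-yl in place of pyridin-3-yl gives a 1.0-fold higher number from compound 1 to compound 3 (0.01 log units; within the scatter). The exchange of sulfur for oxygen in the five-membered aromatic ring therefore leaves the number within the scatter, and the three aromatic rings on a double-bonded chain carbon bound to a double-bonded ring carbon cannot be told apart on these numbers. No measurement is available that bears on this flat result.

The compounds shown leave open whether an amine or a longer chain at this place would give a number beyond the scatter of these three. Also open, on these data alone, is whether a methyl ester in place of the carboxylic acid would move the number.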